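The compounds below may be only part of what the source reports. "The series", "measured", "known", "first", "only" and "open" are said of these compounds alone.

Compound 3, `CC(C)(C)CCn1nc(-c2cccs2)c(O)c(C2=NS(=O)(=O)c3cc(NS(C)(=O)=O)ccc3N2)c1=O`, is one of three analogues of a shared core that were assessed in an ADME assay on Huh-7 cells (Homo sapiens) for cytotoxicity, with a stated time of 72 h; on this read-out lower numbers stand for higher toxicity in this test and higher numbers for lower toxicity in this test. For compound 3 the result is only a limit of the assay, > 1000 nM, which is the limit of > 1000 nM in this assay, at which 1 of the 3 values shown sits. Compound 1, `CC(C)CCn1nc(-c2cccs2)c(O)c(C2=NS(=O)(=O)c3cc(CS(C)(=O)=O)ccc3N2)c1=O`, was also examined; its result is likewise a limit of the assay, > 33000 nM, which is the limit of > 33000 nM in this assay, at which 1 of the 3 values shown sits. Compound 2, `CC(C)CCn1nc(-c2cccs2)c(O)c(C2=NS(=O)(=O)c3cc(S(C)(=O)=O)ccc3N2)c1=O`, was included in the set, but for compound 2 the read-out is "not determined" (no result reported). So compound 3 stands at the lower of the two limits that were reached, with no single number among the three entries, and no step between measured compounds can be counted.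

Compound 4, `CS(=O)(=O)Nc1ccc2c(c1)S(=O)(=O)N=C(c1c(O)c(-c3cccs3)nn(Cc3ccc(F)cc3)c1=O)N2`, is the next member, still to be measured in this assay. It differs from compound 3 in one place: 4-fluorophenyl in place of neopentyl on a saturated chain carbon bound to an aromatic nitrogen. Within the data shown here, with no measured step to lean on and only limits in hand, the expectation for compound 4 is a step from compound 3 of a step that the limit leaves unreadable from compound 3 to compound 4, in other words none beyond the scatter, and most likely again a limit. The estimate for compound 4 is 20000 nM, within a range from 3000 nM to 100000 nM.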

Compound 4, half-maximal cytotoxic concentration: > 1000 nM
Compound 4 gave a limit, no number (the forecaster's own chance of this, stated with the estimate: 75%); the middle value lies beyond the limit too.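

Compound 3 and compound 4 each gave only a limit of the assay in this assay, so the change from neopentyl to 4-fluorophenyl yields no readable step. The compounds shown leave open how far either compound's true half-maximal cytotoxic concentration lies beyond its limit, and how the two compare.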